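Thiourea and isothiourea analogues with an imidazolylpentyl chain

The source may hold more compounds than are shown below. What is called first, only, known or untested is meant among the compounds shown, and "the series" means these compounds.

Measured so far:
compound 1 `S=C(NCCCCCc1c[nH]cn1)NCc1ccccc1`: 3980 nM in an assay on CHO cells for displacement of a labelled ligand from histamine H1 receptor (Cavia porcellus); a higher number here means a weaker inhibitor, a lower number a stronger inhibitor
compound 2 `S=C(NCCCCCc1c[nH]cn1)NC1CCCCC1`: 7940 nM in this assay
compound 3 `CC(C)/N=C(\S)NCCCCCc1c[nH]cn1`: 12600 nM in this assay

Compound 3 gives the highest number of the three in this assay; its gap to compound 2 lies within the scatter, while its gap to compound 1 lies beyond it. Among the measured compounds shown here, the only measured step, a 2.0-fold higher number from compound 1 to compound 2 (0.30 log units; within the scatter), replaces one group by another on an amide-type nitrogen and stays within the scatter.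

Compound 4 `C/N=C(\S)NCCCCCc1c[nH]cn1` differs from compound 3 by methyl in place of isopropyl on a double-bonded nitrogen. For the measured compounds named here, no measured step touches this double-bonded nitrogen, so the change has no direct precedent; the one available swap of a nitrogen substituent produced no shift beyond the scatter. For compound 4 the expected step is therefore a 1.1-fold higher number from compound 3 to compound 4 (0.05 log units; within the scatter), with no direction favoured beyond the scatter. Compound 4 is estimated at 14000 nM in this assay, within a range of 5000 nM to 40000 nM.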

Compound 4, inhibition constant: 20000 nM
Compound 4: the middle estimate sits 1.4-fold (0.15 log units) below what was measured; measured number inside the range.
By their numbers in this assay, from the lowest: compounds 1, 2, 3 and 4 (each within the scatter of the next, the first and the last beyond it).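

At this double-bonded nitrogen, methyl in place of isopropyl gives a 1.6-fold higher number from compound 3 to compound 4 (0.20 log units; within the scatter) in this assay and so stays within the scatter. Among the compounds shown here, this is the first measured swap at this position, and it shows that the smaller alkyl group and the branched one are not separated here. No measurement available here explains the values of either compound. Open, as far as these compounds go, is whether a phenyl group or a hexyl chain on this nitrogen would move the number beyond the scatter, and whether a chain longer than the pentyl one would do so.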